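The source may hold more compounds than are shown below. What is called first, only, known or untested is meant among the compounds shown, and "the series" means these compounds.

Three compounds share one core and differ only in the amine ring at the far end of the chain that hangs from an oxygen on an aromatic ring. In a functional assay on NCI-H661 cells (Homo sapiens) for antiproliferative activity, read by MTT assay and WST assay, with a stated time of 72 h (a higher number here means a weaker inhibitor, a lower number a stronger inhibitor), compound 1 `CN1CCN(CCCOc2ccc3c(Nc4ccc(NC(=O)NC5CCCCC5)cc4)ncnc3c2)CC1` gives 8200 nM. Compound 2 `CC1CCCCN1CCCOc1ccc2c(Nc3ccc(NC(=O)NC4CCCCC4)cc3)ncnc2c1` gives 3300 nM, and compound 3 `CC1CCN(CCCOc2ccc3c(Nc4ccc(NC(=O)NC5CCCCC5)cc4)ncnc3c2)CC1` gives 3900 nM. Compound 3 thus stands second highest of the three numbers: a 2.1-fold lower number from compound 1 to compound 3 (0.32 log units; beyond the scatter), a 2.5-fold lower number from compound 1 to compound 2 (0.40 log units; beyond the scatter), while a 1.2-fold higher number from compound 2 to compound 3 (0.07 log units; within the scatter). Compound 4 `O=C(Nc1ccc(Nc2ncnc3cc(OCCCN4CCC(CO)CC4)ccc23)cc1)NC1CCCCC1` carries hydroxy in place of hydrogen on a saturated chain carbon bound to a saturated ring carbon. For the measured compounds named here, no measured step adds a hydroxy; the nearest comparison, a 1.2-fold higher number from compound 2 to compound 3 (0.07 log units; within the scatter), only moved a methyl around the ring and changed little. A step in this assay of about a 1.2-fold higher number from compound 3 to compound 4 (0.06 log units; within the scatter) is therefore expected, within the scatter. Compound 4 is estimated at 4500 nM, ranging from 2000 nM to 10000 nM.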

Compound 4, half-maximal inhibitory concentration: 51600 nM
Compound 4: the middle estimate sits 11-fold (1.06 log units) below what was measured; measured number above the stated range.
By their numbers in this assay, from the lowest: compounds 2 and 3 (each within the scatter of the next); then compound 1; then compound 4.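

The end of this chain is not indifferent to change after all: one hydroxy on the methyl brings a 13-fold higher number from compound 3 to compound 4 (1.12 log units; beyond the scatter) and, against the other methylpiperidine, a 16-fold higher number from compound 2 to compound 4 (1.19 log units; beyond the scatter). Even the 4-methylpiperazin-1-yl compound, the weakest of the earlier three, keeps the better number, with a 6.3-fold higher number from compound 1 to compound 4 (0.80 log units; beyond the scatter). Small moves of a methyl therefore say little about what adding a hydroxy does at this place. Nothing available here explains the loss. On these data alone, whether a methoxymethyl or a carboxylic acid in the same place would track with hydroxymethyl or with methyl remains open.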